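A few compounds are considered here, and "the series" means these few. Any claim that something is new, unique, unknown or untested is made for them only; others in the source may bear on it.

Working notes on the series, all read in a functional assay on MCF7 cells (Homo sapiens) for cytotoxicity, read by sulforhodamine B assay, with a stated time of 72 h; on this read-out higher numbers stand for weaker inhibition and lower numbers for stronger inhibition. Compound 1 (`O=C(Nc1ccc(Nc2ncnc3c2cnn3-c2ccccc2)cc1)Nc1ccccc1Cl`) gives 55100 nM and compound 2 (`O=C(Nc1cccc(Cl)c1)c1ccc(Nc2ncnc3c2cnn3-c2ccccc2)cc1`) gives 1120 nM, while compound 3 (`O=C(Nc1ccc(Cl)c(C(F)(F)F)c1)c1ccc(Nc2ncnc3c2cnn3-c2ccccc2)cc1`) gives 75900 nM in the same test. Compound 3 thus sits at the high end of the numbers, within the scatter of compound 1 and far above compound 2.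

Compound 4 (`O=C(Nc1ccc(Cl)c(C(F)(F)F)c1)c1ccc(Nc2ncnc3c2cnn3-c2ccc(Cl)cc2)cc1`) follows from compound 3 with chloro in place of hydrogen on an aromatic carbon, para to a large group (chloro in place of hydrogen on an aromatic carbon). The phenyl becomes 4-chlorophenyl.

Among the compounds with values here, two measured steps bear on this only indirectly: a 49-fold lower number from compound 1 to compound 2 (1.69 log units; beyond the scatter) and a 68-fold higher number from compound 2 to compound 3 (1.83 log units; beyond the scatter). Both are large, so single changes can move this series strongly, but neither touches the phenyl that changes here. They give no direction for this change, so no step beyond the scatter is expected, though the uncertainty is wide. The expected step is a 1.5-fold lower number from compound 3 to compound 4 (0.18 log units; within the scatter) on this estimate. For compound 4 the estimated value is 50000 nM with an expected range of 10000 nM to 120000 nM in this assay.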

Compound 4, half-maximal inhibitory concentration: 4920 nM
The estimate for compound 4 lay 10-fold (1.01 log units) above the measured number; the whole stated range lies above it.
By their numbers in this assay, from the lowest: compound 2; then compound 4; then compounds 1 and 3 (each within the scatter of the next).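

In this assay, chloro in place of hydrogen on an aromatic carbon, para to a large group, gives a 15-fold lower number from compound 3 to compound 4 (1.19 log units; beyond the scatter) and so marks this phenyl as a place where one added atom can move the number strongly. The earlier steps shown here changed only the carbamoyl link and the group on the amide-type nitrogen, so they did not show that this phenyl also matters. Nothing measured here explains the size of this step.

Going by these compounds, it remains open whether chloro gives a step of similar size with the 3-chlorophenyl of compound 2 on the amide-type nitrogen. On these data alone, it also remains open whether the step is particular to chloro, or whether fluoro, a methoxy group or an amine at the same place would move the number in the same direction.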